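A bromophenyl swap from compound 3 to compound 4

This account rests on a few compounds, and the source may have more. Where it says the series, first, only, none or still open, it means among the compounds named here.

Values so far in a toxicity assay on THP-1 cells (Homo sapiens) for inhibition (a lower number here means that less compound is tolerated, a higher number that more compound is tolerated), each a limit and not a number:
compound 1 `COc1ccc(-c2cnc(NC(=O)c3ccc(O)cc3)n2C)cc1` gives > 100000 nM
compound 2 `Cn1c(-c2ccccc2)cnc1NC(=O)c1cccc(Br)c1` gives > 50000 nM
compound 3 `COc1ccc(-c2cnc(NC(=O)c3ccccc3Br)n2C)cc1` gives > 100000 nM

Compound 3 has no number in this assay, only the limit > 100000 nM, and the other two values shown are limits as well. Compound 4 `COc1ccc(-c2cnc(NC(=O)c3cccc(Br)c3)n2C)cc1` has the same atoms as compound 3, joined differently: 3-bromophenyl in place of 2-bromophenyl on a carbonyl carbon. The change places 3-bromophenyl in place of 2-bromophenyl on a carbonyl carbon. Going by the values given here, the only measured step is a step that the two limits leave unreadable from compound 1 to compound 3, so it offers no size to carry over. Compound 2 also carries the 3-bromophenyl group, and its limit is > 50000 nM. With the limit of > 100000 nM in this assay, at which 2 of the 3 values shown sit, and with compound 2 also at a limit, no step beyond the scatter is expected in this assay, in either direction. The expected step is a number no higher from compound 3 to compound 4 (the limit leaves the size open). For compound 4 the estimate is 100000 nM, with an expected range from 50000 nM to 200000 nM, most likely reported only as a limit.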

Compound 4, half-maximal cytotoxic concentration: > 100000 nM
Compound 4: a limit, no number; the forecaster's own chance of this, stated with the estimate: 90%; the middle value lies on the limit itself.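

In this assay, going by these compounds alone, compound 4 gives > 100000 nM, a limit and not a number, so no step from compound 1, compound 2 or compound 3 to compound 4 can be read. The compounds shown leave open at what concentration any of them reaches half-maximal cytotoxicity.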